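Swapping the amide for a halogenated ring at the ring carbon

A few compounds are considered here, and "the series" means these few. Any claim that something is new, unique, unknown or untested is made for them only; others in the source may bear on it.

Of the compounds shown here, three sharing one core have been measured in a functional assay on HEK293 cells for agonist activity at G-protein coupled receptor 39 (Homo sapiens), read by scintillation proximity assay and inositol phosphate accumulation, with a stated time of 75 min, in the presence of a further agent that is not named here; on this read-out lower numbers stand for an effect already at smaller amounts and higher numbers for an effect only at larger amounts of compound. Compound 1 `Cc1nn(-c2ncnc3nc[nH]c23)c2c1C(OCc1ccc(Cl)cc1Cl)CC(=O)N2` gives 4 nM, compound 2 `CCCCCCCCOC1CC(=O)Nc2c1c(C)nn2-c1ncnc2nc[nH]c12` gives 8 nM, and compound 3 `Cc1nn(-c2ncnc3nc[nH]c23)c2c1C(NC(=O)c1ccccc1)CC(=O)N2` gives 3 nM. Among the measured compounds shown here, compound 3 has the lowest of the three numbers, yet its separation from compound 1 is within the scatter, so the two cannot be ranked; only the step of a 2.7-fold lower number from compound 2 to compound 3 (0.43 log units; beyond the scatter) is beyond it, and even that is modest.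

Compound 4 `Cc1nn(-c2ncnc3nc[nH]c23)c2c1C(c1ccc(F)cc1Cl)CC(=O)N2` has not been measured. It differs from compound 3 in one place: 2-chloro-4-fluorophenyl in place of benzamido on a saturated ring carbon.

For the measured compounds named here, no measured step makes exactly this exchange, so the expectation rests on how much the numbers moved when the group on this ring carbon was varied before. The step of a 1.3-fold lower number from compound 1 to compound 3 (0.12 log units; within the scatter) shows that a halogenated ring held through an oxygen and a chain carbon and a benzamido give much the same number, and the step of a 2.7-fold lower number from compound 2 to compound 3 (0.43 log units; beyond the scatter) shows that even a long chain at this position shifts the number only modestly. A directly attached 2-chloro-4-fluorophenyl is therefore expected to leave compound 4 close to compound 3 in this assay, with the estimated step of a 1.7-fold higher number from compound 3 to compound 4 (0.22 log units; within the scatter) not beyond the scatter. Compound 4 is expected to give about 5 nM, within a range from 1.5 nM to 16 nM.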

Compound 4, half-maximal effective concentration: 9 nM
Estimate against measurement, compound 4: 1.8-fold (0.26 log units) below; the range from low to high includes it.
By their numbers in this assay, from the lowest: compounds 3, 1, 2 and 4 (each within the scatter of the next, the first and the last beyond it).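

The directly attached 2-chloro-4-fluorophenyl gives the first sign that a ring-bearing group on this saturated ring carbon can separate from the benzamido, with a 3.0-fold higher number from compound 3 to compound 4 (0.48 log units; beyond the scatter) in this assay, a shift that remains modest. A halogenated phenyl ring is also not simply interchangeable here, as a 2.3-fold higher number from compound 1 to compound 4 (0.35 log units; beyond the scatter) shows, although this exchange removes the oxygen and chain carbon and also alters the halogens, so the shift cannot be assigned to either alone. The octyloxy and 2-chloro-4-fluorophenyl groups, very different in shape on paper, cannot be told apart, with a 1.1-fold higher number from compound 2 to compound 4 (0.05 log units; within the scatter), so across these four compounds this position has so far accepted a chain and several ring-bearing groups with only modest shifts.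

Nothing among the available data gives a reason for these shifts. Still open, as far as these compounds go, is how an unsubstituted phenyl attached directly to this carbon would compare, which would help separate the effect of the halogens from that of the direct attachment, and whether an amine or a carboxylic acid here would produce a larger shift.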